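Working notes: tolerated concentration across a small series

A few compounds are considered here, and "the series" means these few. Any claim that something is new, unique, unknown or untested is made for them only; others in the source may bear on it.

Measured so far:
compound 1 `Cc1cn([C@@H]2O[C@H](CO[Si](C)(C)C(C)(C)C)[C@@]3(OS(=O)(=O)C=C3NC(=O)NC(=O)c3ccccc3)[C@H]2O[Si](C)(C)C(C)(C)C)c(=O)n(C)c1=O`, giving >= 80000 nM in an ADME assay on HEL cells (Homo sapiens) for cytotoxicity, with a stated time of 3 days (a lower number here means that less compound is tolerated, a higher number that more compound is tolerated), a limit of the assay.
compound 2 `Cc1cn([C@@H]2O[C@H](CO[Si](C(C)C)(C(C)C)C(C)C)[C@@]3(OS(=O)(=O)C=C3NC(=O)NC(=O)c3ccccc3)[C@H]2O[Si](C)(C)C(C)(C)C)c(=O)n(C)c1=O`, giving >= 100000 nM in this assay, also a limit.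

The step that the two limits leave unreadable from compound 1 to compound 2 cannot be read. Compound 1 stands at a limit (the limit of >= 80000 nM in this assay, at which 1 of the 2 values shown sits). Going by the values given here, the one other value shown is likewise a limit (the limit of >= 100000 nM in this assay, at which 1 of the 2 values shown sits). Compound 3 `CCOC(=O)NC(=O)NC1=CS(=O)(=O)O[C@@]12[C@@H](CO[Si](C)(C)C(C)(C)C)O[C@@H](n1cc(C)c(=O)n(C)c1=O)[C@@H]2O[Si](C)(C)C(C)(C)C` differs from compound 1 by ethoxy in place of phenyl on a carbonyl carbon. No measured step bears on this change, and the single step shown is unreadable, so no step beyond the scatter is expected in this assay; a limit is again expected. Compound 3 is estimated at 80000 nM (40000 nM to 100000 nM), an expected step of a number no higher from compound 1 to compound 3 (the limit leaves the size open).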

Compound 3, minimum cytotoxic concentration: 10000 nM
Estimate against measurement, compound 3: 8.0-fold (0.90 log units) above, outside the stated range (below it).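

In this assay, going by these compounds alone, ethoxy in place of phenyl on a carbonyl carbon gives an at least 8.0-fold lower number from compound 1 to compound 3 (0.90 log units; beyond the scatter), the first readable step, and its full size stays open since the value of compound 1 is a limit. The tolerated concentration thus responds to this place, whereas the step between compound 1 and compound 2 cannot be read. Nothing measured here accounts for the change. On these data alone, whether the lower number follows the loss of phenyl or the entry of ethoxy stays open. So does how a butoxy chain or an amine on this carbonyl carbon would read.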